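The compounds below may be only part of what the source reports. "The series", "measured", "known", "first", "only" and "open" are said of these compounds alone.

Compound 1, whose structure is `COc1cc(-c2nnc3n2NC(c2ccco2)C(C(=O)C2CC2)S3)cc(OC)c1OC`, is the starting point. In a functional assay on HepG2 cells (Homo sapiens) for cytotoxicity, read by MTT assay, with a stated time of 48 h (on this read-out lower numbers stand for stronger inhibition and higher numbers for weaker inhibition), compound 1 gives > 100000 nM, which is a limit of the assay and not a number. Two close relatives have also been tested. Compound 2, `COc1cc(-c2nnc3n2NC(c2ccco2)C(C(=O)c2cccs2)S3)cc(OC)c1OC`, gives 64100 nM in this assay. Compound 3, `COc1cc(-c2nnc3n2NC(c2ccco2)C(C(=O)c2ccc(-c4ccccc4)cc2)S3)cc(OC)c1OC`, gives > 100000 nM, again a limit rather than a number. The picture is shaped by the limit of > 100000 nM in this assay, at which 2 of the 3 values shown sit. Among the steps, an at least 1.5-fold lower number from compound 1 to compound 2 (0.19 log units; that floor lies within the scatter), a step that the two limits leave unreadable from compound 1 to compound 3, and an at least 1.5-fold higher number from compound 2 to compound 3 (0.19 log units; that floor lies within the scatter).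

The compound not yet measured is compound 4, `COc1cccc(C(=O)C2Sc3nnc(-c4cc(OC)c(OC)c(OC)c4)n3NC2c2ccco2)c1`. It differs from compound 1 by 3-methoxyphenyl in place of cyclopropyl on a carbonyl carbon. Among the measured compounds shown here, the steps that bear on it are the two other swaps at the same carbonyl carbon, from compound 1 to compound 2 and from compound 1 to compound 3, and neither reached beyond the scatter or was readable at all. No step beyond the scatter is therefore expected, and a number no higher from compound 1 to compound 4 (the limit leaves the size open) is the estimate. Compound 4 is expected to give about 100000 nM in this assay, within 40000 nM to 400000 nM.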

Compound 4, half-maximal inhibitory concentration: > 100000 nM
Compound 4: no number, only a limit (the forecaster's own chance of this, stated with the estimate: 60%); the middle value lies on the limit itself.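

The 3-methoxyphenyl group now joins cyclopropyl and 4-phenylphenyl at the same limit in this assay, so three quite different groups on this carbonyl carbon give no number, with compound 2 the only exception. The steps from compound 1 and from compound 3 to compound 4 cannot be read, because each pair has limits at both ends: the limit of > 100000 nM in this assay, at which 3 of the 4 values shown sit.

The one readable step is an at least 1.5-fold higher number from compound 2 to compound 4 (0.19 log units; that floor lies within the scatter), so thiophen-2-yl is not shown to stand clearly apart from 3-methoxyphenyl.

The compounds leave open how far above the limit the true values of compound 1, compound 3 and compound 4 lie. They also leave open what an amine, a carboxylic acid or a longer chain on this carbonyl carbon would give, and whether any group there would give a clearly lower number than compound 2.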